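Methyl in Place of Chloro at the Second Halogen Position

This account rests on a few compounds, and the source may have more. Where it says the series, first, only, none or still open, it means among the compounds named here.

Compound 1, `COC(=O)C(=N)/C=C(\O)c1ccc(Cl)cc1`: 13% in an assay for inhibition of kynurenine 3-monooxygenase (Rattus norvegicus), tested at 10 uM; a lower number here means less inhibition, a higher number more inhibition at the concentration tested (going by the name of the read-out)
Compound 2, `COC(=O)C(=N)/C=C(\O)c1ccc(Cl)c(Cl)c1`: 37%
Compound 3, `COC(=O)C(=N)/C=C(\O)c1ccc(F)c(Cl)c1`: 4%

Compound 2 stands highest of the three in this assay. Its nearest neighbour is compound 1, separated from it by the step of a number 24 percentage points higher from compound 1 to compound 2 (beyond the scatter); the furthest is compound 3, reached by the step of a number 33 percentage points lower from compound 2 to compound 3 (beyond the scatter). Both steps lie beyond the scatter, so compound 2 has the highest number of the measured set.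

Compound 4, `COC(=O)C(=N)/C=C(\O)c1ccc(Cl)c(C)c1`, is the next compound to be measured in this assay. It differs from compound 2 in one place: methyl in place of chloro on an aromatic carbon.

For the measured compounds named here, two measured steps bear on this change, and both touch the same aromatic carbon. Going from compound 1 to compound 2 adds a chloro group there and raises the read-out by a modest amount, a number 24 percentage points higher from compound 1 to compound 2 (beyond the scatter). Going from compound 2 to compound 3 trades that chloro for fluoro and lowers it by a large amount, a number 33 percentage points lower from compound 2 to compound 3 (beyond the scatter). Every measured departure from chloro at this carbon has lowered the number in this assay, so for compound 4 a downward step is expected, a number 17 percentage points lower from compound 2 to compound 4 (beyond the scatter), of moderate size. Compound 4 is therefore estimated at 20% in this assay, with a likely range from 5% to 38%.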

Compound 4, a percentage reported as inhibition, at one concentration (the size of the read-out at that concentration, not a potency): 0%
For compound 4 the middle estimate is 20 percentage points above the measured one, and the stated range ends above it.
By their numbers in this assay, from the lowest: compounds 4, 3 and 1 (each within the scatter of the next, the first and the last beyond it); then compound 2.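

At this aromatic carbon, ortho to a chloro group, methyl does not stand in for chloro: in this assay the exchange gives a number 37 percentage points lower from compound 2 to compound 4 (beyond the scatter) and removes the whole of the number seen for compound 2. Measured against hydrogen at the same carbon, the two groups go in opposite directions, with chloro giving a number 24 percentage points higher from compound 1 to compound 2 (beyond the scatter) and methyl giving a number 13 percentage points lower from compound 1 to compound 4 (beyond the scatter) as its counterpart, so placing a group on this carbon does not by itself raise the number. Chloro and methyl have the same counts of heavy atoms, hydrogen-bond donors and hydrogen-bond acceptors, so those counts do not separate them, and no evidence at hand accounts for the difference between the two groups.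

The compounds shown leave open whether any group other than chloro at this carbon, such as bromo, methoxy, an amine or a nitrile, would match or pass the number of compound 2. They also leave open how these differences would appear as potencies, as each compound is described here by its inhibition at one concentration only.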